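Sulfonamide piperidine amides: swapping the amide partner

This account rests on a few compounds, and the source may have more. Where it says the series, first, only, none or still open, it means among the compounds named here.

Compound 1 `O=C([C@@H]1CCCN(S(=O)(=O)c2ccc(S(=O)(=O)C3CCC3)cc2)C1)N1CCC(F)(F)CC1` gives 12.6 nM in a functional assay on MIA PaCa-2 cells (Homo sapiens) for inhibition, read by MTT assay, with a stated time of 3 days; on this read-out lower numbers stand for stronger inhibition and higher numbers for weaker inhibition.
Compound 2 `CCN(CC)S(=O)(=O)c1ccc(S(=O)(=O)N2CCC[C@@H](C(=O)N3CCC(O)CC3)C2)cc1` gives 230 nM in this assay.
Compound 3 `CCN(CC)S(=O)(=O)c1ccc(S(=O)(=O)N2CCC[C@@H](C(=O)N3CCC(C(F)(F)F)CC3)C2)cc1` gives 110 nM in this assay.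

Compound 2 has the highest number of the three, so it is the weakest inhibitor here; compound 3 sits nearest to it and compound 1 furthest away. The new compound 4 `CCN(CC)S(=O)(=O)c1ccc(S(=O)(=O)N2CCC[C@@H](C(=O)N[C@@H]3CCOC3)C2)cc1` differs from compound 2 by (oxolan-3-yl)amino in place of 4-hydroxypiperidin-1-yl on a carbonyl carbon. Within the data shown here, one measured step touches the same carbonyl carbon: a 2.1-fold lower number from compound 2 to compound 3 (0.32 log units; beyond the scatter), a modest gain from replacing a hydroxy group with a trifluoromethyl group on the saturated ring. Compound 1 also carries a different group on that carbonyl, but it changes elsewhere as well, so only its value can be compared. The move to (oxolan-3-yl)amino keeps one hydrogen-bond donor and one acceptor and shrinks the ring, a change with no direct precedent among these compounds, so compound 4 is expected to land close to compound 2, with the step of a 1.1-fold higher number from compound 2 to compound 4 (0.04 log units; within the scatter) estimated to stay within the scatter. The estimate for compound 4 in this assay is therefore 250 nM, ranging from 80 nM to 800 nM.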

Compound 4, half-maximal inhibitory concentration: 100 nM
Compound 4: the middle estimate sits 2.5-fold (0.40 log units) above what was measured; measured number inside the range.
By their numbers in this assay, from the lowest: compound 1; then compounds 4 and 3 (each within the scatter of the next); then compound 2.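

In this assay, putting (oxolan-3-yl)amino in place of 4-hydroxypiperidin-1-yl on the carbonyl carbon gives a 2.3-fold lower number from compound 2 to compound 4 (0.36 log units; beyond the scatter), so this position responds to a change even when the counts of hydrogen-bond donors and acceptors stay the same. The other new step, a 1.1-fold lower number from compound 3 to compound 4 (0.04 log units; within the scatter), shows that (oxolan-3-yl)amino and 4-(trifluoromethyl)piperidin-1-yl, two very different groups, cannot be told apart in this read-out. No measurement at hand explains either result.

The compounds shown cannot separate the effect of the smaller five-membered ring from that of the new attachment through nitrogen. As far as these compounds go, it also remains open how the opposite stereocentre of the oxolan-3-yl group, or a carboxylic acid or a primary amine on the ring, would behave at this position.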